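Chloro to fluoro on the 4-chlorophenyl group

A few compounds are considered here, and "the series" means these few. Any claim that something is new, unique, unknown or untested is made for them only; others in the source may bear on it.

In a functional assay on MCF7 cells (Homo sapiens) for antiproliferative activity, read by MTT assay, with a stated time of 48 h (on this read-out lower numbers stand for stronger inhibition and higher numbers for weaker inhibition), compound 1 (`Cc1ccc(-c2nn(-c3ccccc3)cc2C(Nc2nc3ccccc3s2)c2c(O)ccc3ccccc23)cc1`) gives 13100 nM and compound 2 (`COc1ccc2nc(NC(c3cn(-c4ccccc4)nc3-c3ccc(Cl)cc3)c3c(O)ccc4ccccc34)sc2c1`) gives 23700 nM as its value, so these two numbers sit within the usual scatter of each other. The structure of compound 3 (`COc1ccc2nc(NC(c3cn(-c4ccccc4)nc3-c3ccc(F)cc3)c3c(O)ccc4ccccc34)sc2c1`) differs from compound 2 at one place (fluoro in place of chloro on an aromatic carbon), with fluoro in place of chloro on an aromatic carbon, para to a large group. Among the measured compounds shown here, no measured pair shows this change alone, and no step beyond the scatter is expected in this assay for it. The expected size is a 1.2-fold lower number from compound 2 to compound 3 (0.10 log units; within the scatter) in this estimate. The estimate for compound 3 is 19000 nM with an expected range from 9000 nM to 42000 nM around it.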

Compound 3, half-maximal inhibitory concentration: 16900 nM
The estimate for compound 3 lay 1.1-fold (0.05 log units) above the measured number; measured number inside the range.
By their numbers in this assay, from the lowest: compounds 1, 3 and 2 (each within the scatter of the next).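

Going from 4-chlorophenyl to 4-fluorophenyl in this assay gives a 1.4-fold lower number from compound 2 to compound 3 (0.15 log units; within the scatter) and is the first one-place step read at this position. The chloro and fluoro compounds therefore cannot be told apart on this read-out, so this exchange of one halogen for the other leaves antiproliferative activity without a readable change. Nothing at hand bears on the reason for this result.

On these data alone, what an amine or a carboxylic acid at this place on the phenyl ring would do remains open. The compounds shown also give no one-place step for the methoxy group on the shared core.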